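Methoxy to hydroxy at the para-phenyl position: series notes

This account rests on a few compounds, and the source may have more. Where it says the series, first, only, none or still open, it means among the compounds named here.

Measured so far:
Compound 1, `Nc1nc(-c2ccc(Cl)cc2)nc2cn(-c3ccccc3)nc12`, 13%
Compound 2, `COc1ccc(-c2nc(N)c3nn(-c4ccccc4)cc3n2)cc1`, 33%

The two compounds share the same core and differ only in the group on the pendant phenyl ring. In an assay on CHO cells for displacement of a labelled ligand from adenosine receptor A1 (Homo sapiens), read by scintillation counting, with a stated time of 120 min, tested at 1 uM (a higher number here means more inhibition at the concentration tested (going by the name of the read-out), a lower number less inhibition), compound 1 gives 13% and compound 2 gives 33%. Compound 2 thus stands highest of the two numbers measured, its nearest neighbour being compound 1, and the step between them, a number 20 percentage points higher from compound 1 to compound 2 (beyond the scatter), is beyond the scatter though modest in size.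

Compound 3, `Nc1nc(-c2ccc(O)cc2)nc2cn(-c3ccccc3)nc12`, has not yet been measured in this assay. It differs from compound 2 as follows: hydrogen in place of methyl on an oxygen on an aromatic ring. Among the compounds with values here, no measured step concerns the oxygen-bound methyl itself; the single measured step, a number 20 percentage points higher from compound 1 to compound 2 (beyond the scatter), bears only on what sits on the aromatic carbon and so gives no direct guide. Absent such a step, the expectation is a change no larger than the scatter, with no direction favoured. For compound 3 the estimated step is therefore a number 3 percentage points lower from compound 2 to compound 3 (within the scatter). Compound 3 is accordingly expected to give 30%, with a range from 10% to 50%.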

Compound 3, a percentage reported as inhibition, at one concentration (the size of the read-out at that concentration, not a potency): 31%
For compound 3 the middle estimate is 1 percentage points below the measured one; the range from low to high includes it.
By their numbers in this assay, from the lowest: compound 1; then compounds 3 and 2 (each within the scatter of the next).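

In this assay the methyl on the oxygen turns out to matter little at this position: the step is a number 2 percentage points lower from compound 2 to compound 3 (within the scatter), so the 4-methoxyphenyl and 4-hydroxyphenyl compounds cannot be told apart here. The comparison with the chloro compound now rests on two oxygen-bearing groups rather than one, with a number 18 percentage points higher from compound 1 to compound 3 (beyond the scatter) standing alongside the earlier a number 20 percentage points higher from compound 1 to compound 2 (beyond the scatter); among these three compounds, then, an oxygen on this aromatic carbon goes with more inhibition than chloro, and no compound shown goes against this. Nothing in hand accounts for this pattern or for the lack of a difference between methoxy and hydroxy.

The compounds shown leave open whether the pattern depends on the oxygen itself, which an amine or a plain hydrogen on the same aromatic carbon would test, and whether a longer chain on the oxygen, such as ethoxy, would read like methoxy and hydroxy. Going by these compounds, all three readings are also percentages at one concentration, so how the compounds compare in potency remains open.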